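Phenoxy in Place of Tert-Butyl on a Shared Core

This account rests on a few compounds, and the source may have more. Where it says the series, first, only, none or still open, it means among the compounds named here.

Of the compounds shown here, two built on the same core have been measured in a functional assay on CHO cells with metabotropic glutamate receptor 2 (Homo sapiens) as the target, read by GTPgammaS binding; a lower number here means a smaller maximal response, a higher number a larger maximal response. Compound 1 `CCCc1cnc2c(C#N)c(N3CCN(c4ncccn4)CC3)ccn12` gives 248% in this assay. Compound 2 `CC(C)(C)c1ccc(-c2ccn3c(CC(F)(F)F)cnc3c2C#N)cc1` gives 272% in this assay, the higher of the two numbers, and its gap to compound 1 lies beyond the usual scatter of repeated measurements, so compound 2 stands above compound 1 here.

Compound 3 `N#Cc1c(-c2ccc(Oc3ccccc3)cc2)ccn2c(CC(F)(F)F)cnc12` has not yet been measured. It differs from compound 2 in a single place: phenoxy in place of tert-butyl on an aromatic carbon. The change is therefore phenoxy in place of tert-butyl on an aromatic carbon, para to a large group. For the measured compounds named here, no pair of measured compounds shows the effect of such a change, so the expectation rests on compound 2 alone. In this assay a small downward step is expected, a number 22 percentage points lower from compound 2 to compound 3 (beyond the scatter), not clearly beyond the scatter. Compound 3 is thus expected to give 250%, within a range from 190% to 310%.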

Compound 3, largest response reached (Emax), in percent of the reference or control that the assay uses: 200%
Compound 3: the middle estimate sits 50 percentage points above what was measured; the measured number falls inside the stated range.
By their numbers in this assay, from the lowest: compound 3; then compound 1; then compound 2.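

At this aromatic carbon, para to a large group, the choice of substituent clearly matters: phenoxy in place of tert-butyl gives, in this assay, a number 72 percentage points lower from compound 2 to compound 3 (beyond the scatter). Even so, compound 3 still reaches 200%, so a larger group carrying a ring and an oxygen does not abolish the response, though it does lower the maximum. Nothing available explains why the maximal response falls with this change.

The compounds shown cannot separate the part played by the ring of phenoxy from that of its oxygen; a phenyl group or a methoxy group on the same carbon would help to tell the two apart. On these data alone, how an amine or a carboxylic acid at this carbon would behave in this assay also remains open.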